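A few compounds are considered here, and "the series" means these few. Any claim that something is new, unique, unknown or untested is made for them only; others in the source may bear on it.

In a functional assay on A549 cells (Homo sapiens) for inhibition, read by sulforhodamine B assay (a lower number here means a stronger inhibitor of growth, a higher number a weaker inhibitor of growth), the series so far reads as follows:
- compound 1 `O=C1NC(=S)S/C1=C\c1cc(Br)ccc1OCc1ccccc1` at 7000 nM
- compound 2 `CC(C)(C)c1ccc(-c2ccc(OCc3ccccc3)c(/C=C3\SC(=S)NC3=O)c2)cc1` at 2000 nM

Compound 2 holds the lower of the two numbers, with 2000 nM as the current best growth inhibition in the series. Compound 3 `CC(C)(C)c1ccc(-c2ccc(OCc3ccccc3)c(/C=C3\SC(=O)NC3=O)c2)cc1` keeps the benzyloxy and 4-(tert-butyl)phenyl groups of compound 2, and the change is a group of 8 heavy atoms (4 carbon, 1 nitrogen, 2 oxygen, 1 sulfur; one five-membered non-aromatic ring with 2 hetero atoms) in place of a group of 8 heavy atoms (4 carbon, 1 nitrogen, 1 oxygen, 2 sulfur; one five-membered non-aromatic ring with 2 hetero atoms), on an aromatic carbon on that same ring. For the measured compounds named here, the only measured step, a 3.5-fold lower number from compound 1 to compound 2 (0.54 log units; beyond the scatter), swapped bromo for 4-(tert-butyl)phenyl elsewhere on the molecule and so does not touch the group now exchanged. The data therefore hold no direct measure of this change, and no size can be carried over from that step. The expected step is a 1.5-fold higher number from compound 2 to compound 3 (0.18 log units; within the scatter), which is not expected to lie clearly beyond the scatter, though the range stays wide in both directions. Compound 3 is expected at 3000 nM with an estimated range from 1000 nM to 10000 nM in this measurement.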

Compound 3, concentration for 50% growth inhibition: 2000 nM
Beside the measured number, compound 3's estimate is 1.5-fold (0.18 log units) above it, within the range that was stated.
By their numbers in this assay, from the lowest: compounds 2 and 3 (each within the scatter of the next); then compound 1.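

In this assay, for the compounds shown here, no change at the digits printed from compound 2 to compound 3 (within the scatter) gives the first direct reading at this position: the five-membered non-aromatic ring on the aromatic carbon ortho to a benzyloxy group can go from the form with 2 sulfur to the form with 1 sulfur and 2 oxygen with no shift beyond the scatter. The finding holds for this one pair, with the 4-(tert-butyl)phenyl group in place, and the earlier step, which changed a different part of the molecule, could not show it. No supporting data bear on this result, so the flat reading stays without an explanation.

Going by these compounds, whether the same exchange reads the same with bromo in place of 4-(tert-butyl)phenyl remains open. Also open, on these data alone, is how a carboxylic acid would read in place of the five-membered ring on this aromatic carbon.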